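The source may report more compounds than this note shows. Statements on the series, on what has been measured and on what is new or still open speak of the compounds shown alone.

Going by the values given here, in an ADME assay on cells (spleen, Mus musculus, strain C57BL/6) for inhibition, read by flow cytometry and propidium iodide staining, with a stated time of 24 h, at 37 degrees C (on this read-out lower numbers stand for an effect already at smaller amounts and higher numbers for an effect only at larger amounts of compound), compound 3 (`O=C(Cn1cc(C(=O)O)nn1)NCc1ccccc1`) has no single number; it is reported only as "non-toxic" (no number reported) without a figure, so there is no fixed point to step from. Compound 4 (`O=C(O)CCCCc1cn(CC(=O)NCc2ccccc2)nn1`) carries 4-carboxybutyl in place of carboxy on an aromatic carbon. Two relatives do have numbers: compound 1 (`O=C(Cn1cc(CCCCO)nn1)NCc1ccccc1`) gives 1700 uM and compound 2 (`CC(C)(O)c1cn(CC(=O)NCc2ccccc2)nn1`) gives 1600 uM in the same read-out. Among the compounds with values here, the one measured step (a 1.1-fold lower number from compound 1 to compound 2 (0.03 log units; within the scatter)) puts 1-hydroxy-1-methylethyl in place of 4-hydroxybutyl and lies within the scatter. It bears only loosely on this change, so no step size from compound 3 can be expected in this assay and only a value near those two seems reasonable. The estimated value for compound 4 is 1500 uM with an expected range from 600 uM to 4000 uM as the likely span.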

Compound 4, concentration for half-maximal effect: 1080 uM
Beside the measured number, compound 4's estimate is 1.4-fold (0.14 log units) above it, and the stated range covers the measured number.
By their numbers in this assay, from the lowest: compounds 4, 2 and 1 (each within the scatter of the next).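

In this assay, carboxy in place of hydroxy at the end of the chain gives a 1.6-fold lower number from compound 1 to compound 4 (0.20 log units; within the scatter) and so leaves the number essentially unmoved. With 4-carboxybutyl in place of 1-hydroxy-1-methylethyl on the aromatic carbon, the result is a 1.5-fold lower number from compound 2 to compound 4 (0.17 log units; within the scatter) and again no real difference. Compound 4 thus has a figure, whereas compound 3, with carboxy on that same aromatic carbon, is only called "non-toxic", so the step between them cannot be read. Nothing available explains these values. From the compounds shown here alone, whether an amine at the chain end or a longer chain would stay in this range remains open.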